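The source may report more compounds than this note shows. Statements on the series, on what has been measured and on what is new or still open speak of the compounds shown alone.

In a functional assay on A549 cells (Homo sapiens) for cytotoxicity, read by MTT assay, with a stated time of 72 h (on this read-out lower numbers stand for stronger inhibition and higher numbers for weaker inhibition), the measured compounds are:
- compound 1 `Nc1ccccc1NC(=O)c1ccc(CNc2nccc(-c3cnc4ccccn34)n2)cc1` gives 110 nM
- compound 2 `Nc1ccccc1NC(=O)c1ccc(CNc2nccc(-c3cnc4cnccn34)n2)cc1` gives 509 nM

Of these two, compound 2 holds the higher number and so the weaker result. Compound 3 `Cc1nc2ccccn2c1-c1ccnc(NCc2ccc(C(=O)Nc3ccccc3N)cc2)n1` has not yet been measured. It departs from compound 2 as follows: a group of 10 heavy atoms (8 carbon, 2 nitrogen; one five-membered aromatic ring with 2 hetero atoms, one six-membered aromatic ring with 1 hetero atom) in place of a group of 9 heavy atoms (6 carbon, 3 nitrogen; one five-membered aromatic ring with 2 hetero atoms, one six-membered aromatic ring with 2 hetero atoms), on an aromatic carbon on an aromatic carbon of a six-membered aromatic ring with 2 nitrogen. Among the measured compounds shown here, one measured step bears on this: a 4.6-fold higher number from compound 1 to compound 2 (0.67 log units; beyond the scatter), modest but beyond the scatter, when a group with a six-membered aromatic ring with 1 hetero atom gave way to one with 2 hetero atoms. For the measured compounds named here, compound 3 returns to the ring with 1 hetero atom, but its group holds 10 heavy atoms, a size no measured compound carries. A lower number is therefore expected, with the estimated step of a 2.8-fold lower number from compound 2 to compound 3 (0.45 log units; beyond the scatter) in this assay somewhat smaller than the measured one. For compound 3 the estimate is 180 nM, with an expected range from 60 nM to 550 nM.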

Compound 3, half-maximal inhibitory concentration: 439 nM
Beside the measured number, compound 3's estimate is 2.4-fold (0.39 log units) below it; measured number inside the range.
By their numbers in this assay, from the lowest: compound 1; then compounds 3 and 2 (each within the scatter of the next).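

In this assay, a single methyl in place of hydrogen on an aromatic carbon of the group gives a 4.0-fold higher number from compound 1 to compound 3 (0.60 log units; beyond the scatter), so even this small addition weakens the result beyond the scatter. The six-membered aromatic ring with 1 hetero atom therefore does not keep its advantage once the group carries that methyl, as the exchange of groups gives only a 1.2-fold lower number from compound 2 to compound 3 (0.06 log units; within the scatter). No measured evidence accounts for this effect of the methyl.

The compounds shown leave open whether ethyl, chlorine or an amine on that same carbon would give a number like the one for compound 3. They also leave open whether a methyl added to the group of compound 2 would shift its number at all.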